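The compounds below may be only part of what the source reports. "The series", "measured", "known", "first", "only" and "open" are said of these compounds alone.

Working notes on the series. Compound 3 `COC1=C(OC)C(=O)C(CCCCCCCCC(C)(C)C)=C(C)C1=O` stands second highest of the three numbers in a functional assay on CCRF-CEM cells (Homo sapiens) for cytotoxicity, read by trypan blue exclusion, with stated times of 17 h and 6 h, tested at 0.5 uM; a lower number here means a weaker effect, a higher number a stronger effect of the compound at the concentration tested: compound 3 gives 43%, compound 1 `COC1=C(OC)C(=O)C(CCCCCCCCCCN=[N+]=[N-])=C(C)C1=O` gives 21%, and compound 2 `CCCCCCCCCCCCCCCC1=C(C)C(=O)C(OC)=C(OC)C1=O` gives 87%. The next compound, compound 4 `COC1=C(OC)C(=O)C(CCCCCCCCCCC2CCCCC2)=C(C)C1=O`, carries 2-cyclohexylethyl in place of tert-butyl on a saturated chain carbon, eight bonds along the chain from a double-bonded ring carbon. Two measured steps at this position bear on it: a number 44 percentage points lower from compound 2 to compound 3 (beyond the scatter) and a number 22 percentage points higher from compound 1 to compound 3 (beyond the scatter); further out along the chain, a number 66 percentage points higher from compound 1 to compound 2 (beyond the scatter). Shortening the chain-end group from heptyl to tert-butyl cost much of the effect, and the 2-cyclohexylethyl group restores a longer carbon tail, so a step upward in this assay beyond the scatter is expected, though short of compound 2. Compound 4 is estimated at 65% (range 45% to 85%), an expected step of a number 22 percentage points higher from compound 3 to compound 4 (beyond the scatter).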

Compound 4, a percentage reported as activity, at one concentration (the size of the read-out at that concentration, not a potency): 83%
Compound 4: middle estimate off by 18 percentage points, on the low side, and the stated range covers the measured number.
By their numbers in this assay, from the lowest: compound 1; then compound 3; then compounds 4 and 2 (each within the scatter of the next).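

At this place on the chain, this assay shows a number 40 percentage points higher from compound 3 to compound 4 (beyond the scatter) with 2-cyclohexylethyl in place of tert-butyl, and a number 62 percentage points higher from compound 1 to compound 4 (beyond the scatter) with cyclohexyl in place of azido. A chain end carrying a six-membered non-aromatic ring of carbon only cannot be told apart from the straight tail, with a number 4 percentage points lower from compound 2 to compound 4 (within the scatter) for cyclohexyl in place of pentyl. No evidence in hand accounts for these steps.

Going by these compounds, whether an amine or a carboxylic acid at the chain end keeps this level stays open. So does a phenyl ring in place of the cyclohexyl.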